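A Cyclohexyl-to-Fluorophenyl Change at the Ring Amine Nitrogen

The source may hold more compounds than are shown below. What is called first, only, known or untested is meant among the compounds shown, and "the series" means these compounds.

Compound 1 `O=C(CN1CCN(C2CCCCC2)CC1)Nc1nc2c(s1)CCCC2` is the starting point. In an assay on isolated protein for inhibition of long-chain fatty acid transport protein 1 (Mus musculus), read by scintillation counting, with a stated time of 20 min (on this read-out higher numbers stand for weaker inhibition and lower numbers for stronger inhibition), compound 1 gives only a limit of the assay, > 10000 nM. Compound 2 `O=C(CN1CCN(c2ccc(F)cn2)CC1)Nc1nc2c(s1)CCCC2` carries 5-fluoropyridin-2-yl where compound 1 carries cyclohexyl, and in this assay compound 2 gives 600 nM. The resulting step, an at least 16-fold lower number from compound 1 to compound 2 (1.22 log units; beyond the scatter), is the single measured step in this set, and because it sets out from the limit of > 10000 nM in this assay, at which 1 of the 2 values shown sits, its true size may be larger than the number shown.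

Compound 3 `O=C(CN1CCN(c2ccc(F)cc2)CC1)Nc1nc2c(s1)CCCC2` differs from compound 1 in one place: 4-fluorophenyl in place of cyclohexyl on an amine nitrogen in a ring. Among the measured compounds shown here, the change is of the same kind as the one that leads to compound 2, cyclohexyl giving way to a fluorine-bearing six-membered aromatic ring on the same amine nitrogen; the ring entering here is of carbon only. The measured step from compound 1 to compound 2 therefore bears on it, and a large step downward in this assay is expected for compound 3 as well, of the order an at least 11-fold lower number from compound 1 to compound 3 (1.04 log units; beyond the scatter). Compound 3 is estimated at 900 nM, with a range of 250 nM to 3500 nM.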

Compound 3, half-maximal inhibitory concentration in the long-chain fatty acid transport protein 1 assay: 4000 nM
The estimate for compound 3 lay 4.4-fold (0.65 log units) below the measured number; measured number outside the range, above it.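

Among the fluorine-bearing aromatic rings, the choice of ring matters: in the long-chain fatty acid transport protein 1 assay, 4-fluorophenyl in place of 5-fluoropyridin-2-yl on the amine nitrogen gives a 6.7-fold higher number from compound 2 to compound 3 (0.82 log units; beyond the scatter), so compound 2 and compound 3 do not share one level of inhibition. The carbon-only aromatic ring still improves on cyclohexyl, with an at least 2.5-fold lower number from compound 1 to compound 3 (0.39 log units; beyond the scatter), but compound 1 is held only at a limit, so this step too may be larger than the number shown: the limit of > 10000 nM in the long-chain fatty acid transport protein 1 assay, at which 1 of the 3 values shown sits. In a physicochemical assay for lipophilicity, in phosphate buffer, measured as octanol-water partition, at pH 7.4 (on this read-out lower numbers stand for lower lipophilicity and higher numbers for higher lipophilicity), compound 1 gives 3 and compound 3 gives 4.5. The change from cyclohexyl to 4-fluorophenyl also comes with a large rise in lipophilicity: the measured distribution coefficient of compound 1, 3, and of compound 3, 4.5, a number 1.50 log units higher (beyond the scatter).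

Whether the stronger inhibition of compound 2 goes with a lower distribution coefficient stays open, since the compounds shown give that read-out only for compound 1 and compound 3. Also open, as far as these compounds go, is how much of the effect belongs to the fluorine and how much to the ring itself, a question that an unsubstituted phenyl, an unsubstituted pyridin-2-yl or a pyrimidin-2-yl on the same amine nitrogen would address.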